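Replacing the aryl amine on the shared core: compound 3 to compound 4

The source may report more compounds than this note shows. Statements on the series, on what has been measured and on what is new or still open speak of the compounds shown alone.

Three members of the series have been run in an assay on isolated protein for inhibition of Dipeptidyl peptidase 9 (Homo sapiens) (on this read-out higher numbers stand for weaker inhibition and lower numbers for stronger inhibition), and none has given a number. Compound 1 `Cc1ccnc(Nc2cc(N3CCNCC3)nc3ccnn23)c1` sits at the limit of the assay, > 100000 nM. Compound 2 `Clc1ccc(Nc2cc(N3CCNCC3)nc3ccnn23)c(Cl)c1` likewise sits at the limit, > 100000 nM. The step that the two limits leave unreadable from compound 1 to compound 2 is therefore unreadable. Compound 3 `N[C@@H]1CCCN(c2cc(Nc3ccccc3Cl)n3nccc3n2)C1` also returns only the limit, > 100000 nM, so its standing is known solely as the limit of > 100000 nM in this assay, at which 3 of the 3 values shown sit.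

Compound 4 `N[C@@H]1CCCN(c2cc(NCc3ccc(O)cc3)n3nccc3n2)C1` differs from compound 3 in one place: 4-hydroxybenzyl in place of 2-chlorophenyl on a nitrogen on an aromatic ring. Going by the values given here, no measured step in this assay bears on such a change, since every step so far runs between two limits and carries no readable size. With all three measured compounds at the limit, the expectation for compound 4 is that it will most likely return the limit as well, and the step that the limit leaves unreadable from compound 3 to compound 4 is estimated as small or none beyond the scatter. On that basis compound 4 is expected to give about 150000 nM in this assay, with a range from 30000 nM to 1000000 nM.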

Compound 4, half-maximal inhibitory concentration: > 50000 nM
Compound 4 ended at the assay's limit; the forecaster's own chance of this, stated with the estimate: 75%; the middle value lies beyond the limit too.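

In this assay, going by these compounds alone, compound 4 gives > 50000 nM as a limit of the assay, so no step from compound 3 to compound 4 can be read. The compounds shown leave open whether any group on that nitrogen of the shared core gives a measurable value in this assay at all.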